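A few compounds are considered here, and "the series" means these few. Any claim that something is new, unique, unknown or untested is made for them only; others in the source may bear on it.

Measured so far in a functional assay on SK-HEP1 cells (Homo sapiens) for antiproliferative activity, read by sulforhodamine B assay, with a stated time of 72 h; on this read-out higher numbers stand for weaker inhibition and lower numbers for stronger inhibition:

Compound 1, `CC(C)[C@@H](O)[C@H](O)C(=O)NS(=O)(=O)OC[C@H]1O[C@@H](n2cnc3c(N)ncnc32)C[C@@H]1O`, gives 5740 nM.
Compound 2, `CC(C)C[C@H](O)C(=O)NS(=O)(=O)OC[C@H]1O[C@@H](n2cnc3c(N)ncnc32)[C@H](O)[C@@H]1O`, gives 1760 nM.
Compound 3, `CO[C@H](C(=O)NS(=O)(=O)OC[C@H]1O[C@@H](n2cnc3c(N)nc(Cl)nc32)[C@H](O)[C@@H]1O)[C@H](OC)C(C)C`, gives only a limit of the assay, > 20000 nM.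

Compound 2 holds the lowest of the two numbers in this assay. The nearest number is that of compound 1, which is higher by a margin that goes beyond the usual scatter of repeated measurements. For compound 3 only a limit is known, (the limit of > 20000 nM in this assay, at which 1 of the 3 values shown sits), so no number can be placed beside the other two.

Compound 4, `CC(C)C[C@H](O)C(=O)NS(=O)(=O)OC[C@H]1O[C@@H](n2cnc3c(=O)[nH]cnc32)[C@H](O)[C@@H]1O`, has not yet been measured in this assay. It differs from compound 2 in one place: a group of 10 heavy atoms (5 carbon, 4 nitrogen, 1 oxygen; one five-membered aromatic ring with 2 hetero atoms, one six-membered aromatic ring with 2 hetero atoms) in place of a group of 10 heavy atoms (5 carbon, 5 nitrogen; one five-membered aromatic ring with 2 hetero atoms, one six-membered aromatic ring with 2 hetero atoms), on a saturated ring carbon. The rest of compound 2, the hydroxy acyl chain, the sulfamate linkage and the sugar with its two hydroxy groups, is carried over unchanged.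

Going by the values given here, no step between two measured compounds shows the effect of this exchange, so the expectation rests on the position of compound 2 alone and on the width of the present numbers. The step is expected to be a weakening, larger than the scatter, and there is a real chance that compound 4 reaches the limit of the assay. The expected step is a 4.5-fold higher number from compound 2 to compound 4 (0.66 log units; beyond the scatter). Compound 4 is estimated at 8000 nM, with a range from 2500 nM to 20000 nM.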

Compound 4, half-maximal inhibitory concentration: > 20000 nM
Compound 4 was reported as a limit; the forecaster's own chance of this, stated with the estimate: 30%; middle value at least 2.5-fold (0.39 log units) from the limit.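

In this assay compound 4 gives only a limit of the assay, > 20000 nM. With the hydroxy acyl chain, the sulfamate linkage and the sugar carried over unchanged, the exchange on the saturated ring carbon next to the ring oxygen gives an at least 11-fold higher number from compound 2 to compound 4 (1.05 log units; beyond the scatter), so the printed size is a lower bound on a large step. This is the first single-place step in the series; it shows that activity here depends strongly on which of these two groups is present, the entering one having 1 double bond outside aromatic rings and 4 hydrogen-bond acceptors against 5 in the group that leaves, and the series now gathers at the top of the measurable range: the limit of > 20000 nM in this assay, at which 2 of the 4 values shown sit.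

From the compounds shown here alone, what remains open is how a smaller change at the same place would read, such as a methylamino group or a plain hydrogen in place of the carbonyl of compound 4. This single pair also leaves open whether the same exchange would cost as much on another acyl chain or on a sugar with a different number of hydroxy groups.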